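From isopropyl to cyclohexyl at the limit of tolerance

The compounds below may be only part of what the source reports. "The series", "measured", "known", "first", "only" and "open" are said of these compounds alone.

Compound 1 (`Cc1cc(C)cc(S(=O)(=O)c2c(C(=O)NCC(=O)NN)[nH]c3ccc(Cl)cc23)c1`) gives > 100 uM in a functional assay on MT4 cells (Homo sapiens) for cytotoxicity, read by MTT assay (a higher number here means that more compound is tolerated, a lower number that less compound is tolerated), and this is a limit of the assay, not a number. Compound 2 (`Cc1cc(C)cc(S(=O)(=O)c2c(C(=O)NNC(C)C)[nH]c3ccc(Cl)cc23)c1`) gives > 100 uM in this assay and this too is only a limit. Compound 2 therefore has no exact number to start from. For the measured compounds named here, the single measured step is a step that the two limits leave unreadable from compound 1 to compound 2 with isopropylamino in place of (aminocarbamoyl)methyl on an amide-type nitrogen, so no size can be taken from it. Compound 3 (`Cc1cc(C)cc(S(=O)(=O)c2c(C(=O)NNC3CCCCC3)[nH]c3ccc(Cl)cc23)c1`) carries cyclohexyl in place of isopropyl on an amine nitrogen. Going by the values given here, the only guide is the limit of > 100 uM in this assay, at which 2 of the 2 values shown sit, and neither measured compound has yet left that limit. In this assay a modest step toward less compound tolerated is expected, or none beyond the scatter. The expected value for compound 3 is 80 uM with an estimated range from 25 uM to 200 uM in this assay. This estimate means an expected at least 1.2-fold lower number from compound 2 to compound 3 (0.09 log units; that floor lies within the scatter) and the assay may well report only a limit again.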

Compound 3, half-maximal toxic concentration: > 100 uM
Compound 3: a limit, no number (the forecaster's own chance of this, stated with the estimate: 55%); middle value at least 1.2-fold (0.09 log units) away from the limit.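

For the compounds shown here, compound 1, compound 2 and compound 3 all stand only at a limit in this assay, so no step among them can be read and none has a size: the limit of > 100 uM in this assay, at which 3 of the 3 values shown sit. The compounds shown leave open what exact number each would give, and whether any group on this amine nitrogen would bring a compound off the limit.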